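Amide Truncation From Phenyl to Methyl and Cell Tolerability

The source may hold more compounds than are shown below. What is called first, only, known or untested is meant among the compounds shown, and "the series" means these compounds.

Three analogues of the shared core have been tested in a toxicity assay on THP-1 cells (Homo sapiens) for inhibition; a higher number here means that more compound is tolerated, a lower number that less compound is tolerated. Compound 1 `COc1ccc(-c2cnc(NC(=O)C3CCCC3)n2C)cc1` carries a cyclopentyl on the carbonyl carbon, and in this assay compound 1 gives > 100000 nM, which is a limit of the assay. Compound 2 `COc1ccc(-c2cnc(NC(=O)c3ccco3)n2C)cc1` gives > 100000 nM in this assay, again a limit. Compound 3 `COc1ccc(-c2cnc(NC(=O)c3ccccc3)n2C)cc1` gives > 100000 nM in this assay, also a limit. Because all three values sit at the limit described by the limit of > 100000 nM in this assay, at which 3 of the 3 values shown sit, the steps a step that the two limits leave unreadable from compound 1 to compound 2, a step that the two limits leave unreadable from compound 1 to compound 3 and a step that the two limits leave unreadable from compound 2 to compound 3 cannot be sized, and compound 3 stands level with compound 1 and compound 2 as far as the numbers show. Compound 4 `COc1ccc(-c2cnc(NC(C)=O)n2C)cc1` differs from compound 3 by methyl in place of phenyl on a carbonyl carbon. No measured step here has a readable size, so methyl in place of phenyl on a carbonyl carbon has no direct precedent among these compounds. Compound 4 is expected to remain well tolerated, with the step of a number no higher from compound 3 to compound 4 (the limit leaves the size open) expected to stay within the scatter. The estimate for compound 4 is 100000 nM, ranging from 50000 nM to 200000 nM.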

Compound 4, half-maximal cytotoxic concentration: > 100000 nM
Compound 4 was reported as a limit; the forecaster's own chance of this, stated with the estimate: 85%; the middle value lies on the limit itself.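

The steps linking compound 4 to compound 1, compound 2 and compound 3 cannot be read, because all four compounds stand at one limit: the limit of > 100000 nM in this assay, at which 4 of the 4 values shown sit. The compounds shown leave open at what concentration any of them becomes toxic, and whether the group on the carbonyl carbon affects tolerability.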